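A few compounds are considered here, and "the series" means these few. Any claim that something is new, unique, unknown or untested is made for them only; others in the source may bear on it.

Compound 3, `O[C@@H]1[C@@H](OCc2ccccc2)[C@H](OCc2ccccc2)[C@@H](COCc2ccccc2)O[C@@H]1c1ccccc1`, is one of a set of benzyl-protected sugar-like compounds tested for growth inhibition. In a functional assay on HL-60 cells (Homo sapiens) for antiproliferative activity, read by MTT assay (a lower number here means a stronger inhibitor, a higher number a weaker inhibitor), compound 3 gives "not active" (no number reported), so no single number stands for it. It shares this standing with compound 1, `CCCC[C@H]1O[C@H](COCc2ccccc2)[C@@H](OCc2ccccc2)[C@H](OCc2ccccc2)[C@H]1O`, which in this assay gives "not active" (no number reported). Going by the values given here, the only compound of the set with a number is compound 2, `CCC[C@H]1O[C@H](COCc2ccccc2)[C@@H](OCc2ccccc2)[C@H](OCc2ccccc2)[C@H]1O`, which in this assay gives 28200 nM, a weak inhibitor.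

Compound 4, `CC[C@H]1O[C@H](COCc2ccccc2)[C@@H](OCc2ccccc2)[C@H](OCc2ccccc2)[C@H]1O`, is not yet measured. It differs from compound 3 in a single place: ethyl in place of phenyl on a saturated ring carbon. Among the compounds with values here, since compound 3 has no number, no size of step in this assay can be drawn from it; the change moves compound 4 toward the alkyl-bearing members, of which compound 2 shows weak inhibition and compound 1 shows none, so the direction of any step is unknown and only weak activity is expected. Compound 4 is estimated to give about 40000 nM in this assay, within a range from 10000 nM to 200000 nM, with a fair chance that only a limit is reported.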

Compound 4, half-maximal inhibitory concentration: "not active" (no number reported)
No number was reported for compound 4; there is nothing to compare the estimate with.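

Compound 3 and compound 4 both stand without a number in this assay, so the step between them cannot be read. No measurement shown bears on this result. The compounds shown leave open whether exchanging phenyl for ethyl alters antiproliferative activity at all.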